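The source may hold more compounds than are shown below. What is called first, only, known or untested is meant among the compounds shown, and "the series" means these compounds.

In a functional assay on thoracic aorta for antagonist activity at Alpha-1D adrenergic receptor (Rattus norvegicus) (on this read-out lower numbers stand for lower potency and higher numbers for higher potency (the scale is a negative logarithm)), compound 1 `COc1cccc(OC)c1OCCNCCOc1ccccc1OCc1ccccc1Cl` gives 8.59; this sits within the scatter of compound 2 `COc1cccc(OC)c1OCCNCCOc1ccccc1OCc1cccc(Cl)c1`, which gives 8.72, and clearly under compound 3 `COc1cccc(OC)c1OCCNCCOc1ccccc1OCc1ccc([N+](=O)[O-])cc1`, which gives 9.41. Compound 4 `CCOc1ccc(COc2ccccc2OCCNCCOc2c(OC)cccc2OC)cc1` differs from compound 1 in one place: 4-ethoxyphenyl in place of 2-chlorophenyl on a saturated chain carbon bound to an oxygen on an aromatic ring. Among the compounds with values here, two measured steps bear on this exchange, each swapping the same group at the same place: a number 0.13 log units higher from compound 1 to compound 2 (within the scatter) and a number 0.82 log units higher from compound 1 to compound 3 (beyond the scatter). Neither of them brings in 4-ethoxyphenyl, so the size of the coming step is uncertain, yet both earlier swaps moved the number upward, one beyond the scatter, and a small rise is expected. Compound 4 is therefore estimated at 8.9, with a range from 8.4 to 9.5, which would be an expected step of a number 0.31 log units higher from compound 1 to compound 4 (beyond the scatter).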

Compound 4, negative logarithm of the antagonist equilibrium constant: 9.11
Beside the measured number, compound 4's estimate is 0.21 log units below it, within the range that was stated.
By their numbers in this assay, from the lowest: compounds 1 and 2 (each within the scatter of the next); then compounds 4 and 3 (each within the scatter of the next).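

With 4-ethoxyphenyl on this saturated chain carbon, the number moves clearly past both chlorophenyl compounds, with a number 0.52 log units higher from compound 1 to compound 4 (beyond the scatter) and a number 0.39 log units higher from compound 2 to compound 4 (beyond the scatter) as the two steps. Ethoxy in place of nitro on the aromatic carbon gives a number 0.30 log units lower from compound 3 to compound 4 (within the scatter), so two very different groups leave compound 3 and compound 4 indistinguishable here. Nothing measured here explains these steps. Going by these compounds, what a 4-chlorophenyl or a 4-aminophenyl group would give at this place remains open, and with it whether the placement of the group on the ring matters more than its identity.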